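This account rests on a few compounds, and the source may have more. Where it says the series, first, only, none or still open, it means among the compounds named here.

Measured so far:
compound 1, `CCO/N=C/Nc1cc(Cl)c(F)c(Cl)c1`, gives 4 in a physicochemical assay for lipophilicity, measured as octanol-water partition; on this read-out higher numbers stand for higher lipophilicity and lower numbers for lower lipophilicity
compound 2, `C#CCOc1c(Cl)cc(N/C=N/OCC)cc1Cl`, gives 3.6 in this assay
compound 3, `C#CCc1c(Cl)cc(N/C=N/OC)cc1Cl`, gives 3.3 in this assay

In this assay compound 3 stands lowest of the three numbers; its nearest neighbour is compound 2, a gap within the scatter, while the gap to compound 1 lies beyond it. Compound 4, `C#CCc1c(Cl)cc(N/C=N/OCc2ccccc2)cc1Cl`, differs from compound 3 by phenyl in place of hydrogen on a saturated chain carbon bound to an oxygen. Among the compounds with values here, the only single-place step measured, a number 0.40 log units lower from compound 1 to compound 2 (beyond the scatter), concerns another group at another place and does not bear on this change; compounds 2 and 3 differ in two places, and their two values lie within the scatter of each other. Within the data shown here, no measured step speaks to phenyl in place of hydrogen here. The estimate for compound 4 in this assay is 5, between 4.4 and 5.6. The expected step is a number 1.70 log units higher from compound 3 to compound 4 (beyond the scatter).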

Compound 4, partition coefficient: 4.2
Compound 4: middle estimate off by 0.80 log units, on the high side; the measured number lies below the stated range.
By their numbers in this assay, from the lowest: compounds 3 and 2 (each within the scatter of the next); then compounds 1 and 4 (each within the scatter of the next).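

This is the only step shown at this place, and in this assay it reads a number 0.90 log units higher from compound 3 to compound 4 (beyond the scatter). The change of methyl to benzyl, which brings in one six-membered aromatic ring of carbon only, thus raises the number here, something the step from fluoro to propargyloxy at another place could not show. No measurement shown accounts for the size of this step.

From the compounds shown here alone, whether a longer chain or a phenyl ring carrying an amine or a carboxylic acid would move the number the same way remains open. So does whether phenyl would give a similar step on the core of compound 1.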